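Swapping an aromatic ring for a hexyl chain

A few compounds are considered here, and "the series" means these few. Any claim that something is new, unique, unknown or untested is made for them only; others in the source may bear on it.

Of the compounds shown here, three built on a shared core have been measured in a functional assay on KB cells (Homo sapiens) for cytotoxicity, read by MTT assay, with a stated time of 72 h; on this read-out higher numbers stand for weaker inhibition and lower numbers for stronger inhibition. Compound 1 `[O-][n+]1nc(NCOCc2ccc(Cl)cc2)[n+]([O-])c2ccccc21` gives 1300 nM. Compound 2 `COc1ccc(COCNc2n[n+]([O-])c3ccccc3[n+]2[O-])cc1` gives 4060 nM, the highest of the three numbers. Compound 3 `CC(C)CCOCNc1n[n+]([O-])c2ccccc2[n+]1[O-]` gives 3040 nM. Between them, the step of a 3.1-fold higher number from compound 1 to compound 2 (0.49 log units; beyond the scatter) and the step of a 2.3-fold higher number from compound 1 to compound 3 (0.37 log units; beyond the scatter) are both modest, while the step of a 1.3-fold lower number from compound 2 to compound 3 (0.13 log units; within the scatter) stays within the scatter, so compound 2 and compound 3 cannot be told apart on these numbers.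

Compound 4 `CCCCCCCOCNc1n[n+]([O-])c2ccccc2[n+]1[O-]` differs from compound 2 in one place: hexyl in place of 4-methoxyphenyl on a saturated chain carbon bound to an oxygen on a saturated carbon. The closest guide is the step from compound 2 to compound 3, where another saturated chain replaced the same 4-methoxyphenyl group at the same place and the number barely moved, as a 1.3-fold lower number from compound 2 to compound 3 (0.13 log units; within the scatter) shows. The step of a 2.3-fold higher number from compound 1 to compound 3 (0.37 log units; beyond the scatter) also shows a saturated chain taking the place of an aromatic group with only a modest effect. The expected step is therefore a 1.2-fold lower number from compound 2 to compound 4 (0.09 log units; within the scatter), not beyond the scatter. Compound 4 is estimated at 3300 nM, with a range from 1500 nM to 7500 nM.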

Compound 4, half-maximal inhibitory concentration: 2520 nM
Beside the measured number, compound 4's estimate is 1.3-fold (0.12 log units) above it; the range from low to high includes it.
By their numbers in this assay, from the lowest: compounds 1, 4, 3 and 2 (each within the scatter of the next, the first and the last beyond it).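

In this assay, the hexyl chain has no ring, yet a 1.6-fold lower number from compound 2 to compound 4 (0.21 log units; within the scatter) and a 1.9-fold higher number from compound 1 to compound 4 (0.29 log units; within the scatter) both stay within the scatter, so at this place the six-membered aromatic ring can be lost without a change these numbers can resolve. Among the saturated chains, the change from compound 3 to compound 4 is no clearer, as a 1.2-fold lower number from compound 3 to compound 4 (0.08 log units; within the scatter) also stays within the scatter. Compound 3 lies beyond the scatter from compound 1 and compound 4 does not, but this contrast means little, since compound 3 and compound 4 cannot be told apart.

Going by these compounds, whether an amine, a carboxylic acid or a much longer chain at this place would move the number beyond the scatter remains open. No supporting evidence is available to explain these results.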